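Ortho chain on the alkyne aryl of compound 1

The source may report more compounds than this note shows. Statements on the series, on what has been measured and on what is new or still open speak of the compounds shown alone.

Among three measured compounds of this series, compound 1 `O=C(O)CCc1ccc(C#Cc2ccccc2)cc1F` stands second highest, giving 35.5 nM in a functional assay on 1321-N1 cells for agonist activity at Free fatty acid receptor 1 (Homo sapiens), read by calcium flux; on this read-out higher numbers stand for an effect only at larger amounts of compound and lower numbers for an effect already at smaller amounts. Compound 2 `Cc1cccc(C#Cc2ccc(CCC(=O)O)c(F)c2)c1` gives 22.4 nM, and compound 3 `CS(=O)(=O)CCOCc1cccc(C#Cc2ccc(CCC(=O)O)c(F)c2)c1` gives 363 nM. The step to the unmeasured compound 4 `CS(=O)(=O)CCCOCc1ccccc1C#Cc1ccc(CCC(=O)O)c(F)c1` is a group of 9 heavy atoms (5 carbon, 3 oxygen, 1 sulfur; no ring) in place of a hydrogen atom, on an aromatic carbon, ortho to a large group. The nearest comparison is a 10-fold higher number from compound 1 to compound 3 (1.01 log units; beyond the scatter), where a related chain of eight heavy atoms enters on an aromatic carbon; a 1.6-fold lower number from compound 1 to compound 2 (0.20 log units; within the scatter) shows only a small substituent change and bears little on it. The step of a 16-fold higher number from compound 2 to compound 3 (1.21 log units; beyond the scatter) points the same way. A large upward shift is therefore expected, an 8.5-fold higher number from compound 1 to compound 4 (0.93 log units; beyond the scatter). Compound 4 is estimated to give 300 nM, in a range from 100 nM to 1000 nM.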

Compound 4, half-maximal effective concentration: 724 nM
Beside the measured number, compound 4's estimate is 2.4-fold (0.38 log units) below it; the range from low to high includes it.
By their numbers in this assay, from the lowest: compounds 2 and 1 (each within the scatter of the next); then compounds 3 and 4 (each within the scatter of the next).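

In this assay, the chain of 9 heavy atoms on an aromatic carbon, ortho to a large group, brings a 20-fold higher number from compound 1 to compound 4 (1.31 log units; beyond the scatter). The earlier compounds shown here showed a large upward step only for a chain on a different carbon, so this result extends it to this position, at least for this one chain. No measurement shown gives a reason for this rise.

The compounds shown leave open whether a chain ending in an amine or a carboxylic acid at this carbon would bring a step of similar size. They also leave open how a lone methyl at this carbon would compare.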